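The source may hold more compounds than are shown below. What is called first, only, known or untested is meant among the compounds shown, and "the series" means these compounds.

Measured so far:
- compound 1 `C=C[C@@]1(C)C=C(C)[C@@H]2[C@@H]3[C@H](Oc4ccc(cc4)C[C@@H]4C(=O)NC(=O)[C@@H]4C(=O)[C@H]31)[C@@H]1[C@@H](C)C[C@@H](C)C[C@]12C`: in an assay on isolated protein for inhibition of receptor-type tyrosine-protein phosphatase F (Homo sapiens) (on this read-out higher numbers stand for weaker inhibition and lower numbers for stronger inhibition), compound 1 gives > 200000 nM, which is a limit of the assay rather than a measured number.
- compound 2 `CO[C@@]12Cc3ccc(cc3)O[C@H]3[C@H]([C@H]4C(=O)[C@](C[C@@H](O)[C@]4(C)C=O)(C1)C(=O)N2)[C@@H](C(C)=O)[C@]1(C)C[C@H](C)C[C@H](C)[C@@H]31`: in this assay compound 2 gives > 200000 nM, again a limit of the assay and not a number.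

Within the data shown here, compound 2 therefore does not stand at any measured point at all: its result is only a limit, and the one other value shown is a limit of the same kind, so nothing within these data tells the two compounds apart. Both sit at the limit of > 200000 nM in this assay, at which 2 of the 2 values shown sit.

Compound 3 `CC(=O)[C@@H]1[C@@H]2[C@H](Oc3ccc(cc3)C[C@]3(O)C[C@]4(C[C@@H](O)[C@](C)(C=O)[C@@H]2C4=O)C(=O)N3)[C@@H]2[C@@H](C)C[C@@H](C)C[C@]21C` has not yet been measured. It differs from compound 2 in one place: hydrogen in place of methyl on an oxygen on a saturated carbon; read one bond further out, the change is methoxy to hydroxy.

Among the measured compounds shown here, no step between two measured compounds has been recorded here, so there is no measured change to lean on. With compound 2 at a limit, the step from compound 2 to compound 3 is expected to be small or none beyond the scatter, shown as a step that the limit leaves unreadable from compound 2 to compound 3. Compound 3 is accordingly expected to give 300000 nM, with a range from 50000 nM to 1500000 nM, and most likely once more only a limit.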

Compound 3, half-maximal inhibitory concentration: > 200000 nM
Compound 3 gave a limit, no number; the forecaster's own chance of this, stated with the estimate: 85%; the middle value lies beyond the limit too.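

In this assay compound 3 gives > 200000 nM, which is a limit and not a number. Compound 2 also stands at a limit, so no step can be read for the change from methoxy to hydroxy between compound 2 and compound 3. The compounds shown leave open how strongly any of them inhibits, and whether that change matters at all: the limit of > 200000 nM in this assay, at which 3 of the 3 values shown sit.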